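Replacing 5-cyanopentyl with pyrazin-2-yl on the shared core

This account rests on a few compounds, and the source may have more. Where it says the series, first, only, none or still open, it means among the compounds named here.

In a physicochemical assay for solubility, in phosphate buffer, with a stated time of 18 h (a higher number here means a more soluble compound, a lower number a less soluble compound), compound 1 (`N#Cc1c(N)nc2nc(C3CC3)ncc2c1N`) gives 23000 nM, and compound 2 (`N#Cc1c(N)nc2nc(C3CCC3)ncc2c1N`) gives 217000 nM. Compound 3 (`CC(C)(C)c1nc(CCCCCC#N)c2c(N)c(C#N)c(N)nc2n1`) gives 6000 nM, the lowest of the three numbers, and its gap to each of the other two lies beyond the scatter. Compound 4 (`CC(C)(C)c1nc(-c2cnccn2)c2c(N)c(C#N)c(N)nc2n1`) has not yet been measured. It differs from compound 3 by pyrazin-2-yl in place of 5-cyanopentyl on an aromatic carbon.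

Among the compounds with values here, only one measured step is available, a 9.4-fold higher number from compound 1 to compound 2 (0.97 log units; beyond the scatter), with cyclobutyl in place of cyclopropyl on an aromatic carbon. Within the data shown here, no measured step involves either 5-cyanopentyl or pyrazin-2-yl, so this step bears on the change only indirectly. It shows that exchanging one group can shift the number modestly, beyond the scatter. Among the measured compounds shown here, with compound 3 at 6000 nM, the low end of the numbers so far, the direction is more likely upward, though this is a weak guide. The expected step is a 2.5-fold higher number from compound 3 to compound 4 (0.40 log units; beyond the scatter), a modest rise of no greater size than the measured one. For compound 4 the estimated value is 15000 nM, with an expected range from 3000 nM to 70000 nM.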

Compound 4, solubility: 86000 nM
The estimate for compound 4 lay 5.7-fold (0.76 log units) below the measured number, outside the stated range (above it).
By their numbers in this assay, from the lowest: compound 3; then compound 1; then compound 4; then compound 2.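

With the rest of the molecule held constant, replacing 5-cyanopentyl with pyrazin-2-yl in this assay gives a 14-fold higher number from compound 3 to compound 4 (1.16 log units; beyond the scatter) and is a large step. Within the data shown here, this is the first measured change at this aromatic carbon, next to the ring nitrogen and meta to the tert-butyl group, and it shows that the number responds strongly to the group placed there. The swap hardly alters the heavy-atom count, 6 in place of 7, yet it exchanges an open chain ending in a nitrile for a six-membered aromatic ring with 2 hetero atoms, and no measurement shown explains the rise.

The compounds shown include no phenyl group at this position and no alkyl chain lacking the nitrile, so it remains open whether the rise goes with the aromatic ring, its ring nitrogens or the loss of the nitrile. On these data alone, it is also open whether the same exchange would give a similar step with cyclopropyl or cyclobutyl in place of the tert-butyl group.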